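The source may report more compounds than this note shows. Statements on the series, on what has been measured and on what is new or still open speak of the compounds shown alone.

Measured so far in an ADME assay on microsomes from liver (Homo sapiens) for metabolic stability, read by HPLC, using NADPH, with stated times of 10 min and 60 min; a higher number here means that more of the compound is left, a lower number that less of the compound is left:
- Compound 1 `Cc1ccc(NC(=O)CCCn2cc(-c3ccc(C(F)(F)F)cc3)nn2)cc1` gives 84%
- Compound 2 `COC(=O)c1ccc(-c2cn(CCCC(=O)Nc3ccc(-c4ccccc4)cc3)nn2)cc1` gives 87%
- Compound 3 `Cc1ccc(NC(=S)CCCn2cc(-c3ccc(C(F)(F)F)cc3)nn2)cc1` gives 73%

Compound 3 has the lowest of these three numbers, and compound 1 and compound 2 both stand higher by more than the usual scatter. The next compound to be measured is compound 4 `FC(F)(F)c1ccc(-c2cn(CCCC(=S)Nc3ccc(-c4ccccc4)cc3)nn2)cc1`, which differs from compound 3 by a single swap (phenyl in place of methyl on an aromatic carbon): phenyl in place of methyl on an aromatic carbon.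

For the measured compounds named here, no measured pair isolates this swap. The closest hint comes from compound 1 (methyl, 84%) and compound 2 (phenyl, 87%), whose values lie within the scatter of each other, although the two also differ elsewhere. On that thin evidence, the expected result in this assay is no step beyond the scatter, with an estimated no change at the digits printed from compound 3 to compound 4 (within the scatter) as the likely outcome. The value expected for compound 4 is 73% within an estimated range of 56% to 87% as a rough guide.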

Compound 4, percent of the compound remaining: 80%
Compound 4: middle estimate off by 7 percentage points, on the low side; the measured number falls inside the stated range.
By their numbers in this assay, from the lowest: compounds 3, 4, 1 and 2 (each within the scatter of the next, the first and the last beyond it).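

In this assay, for the compounds shown here, phenyl in place of methyl on an aromatic carbon gives a number 7 percentage points higher from compound 3 to compound 4 (within the scatter) and this is the first pair of compounds that differ in this one place alone. At this position, para to a large group, a whole six-membered aromatic ring can therefore stand where a single methyl stood, with no step beyond the usual scatter in how much compound remains. Nothing available gives a reason for this result.

This single pair cannot show whether the same swap would read the same way with the rest of the molecule changed. The compounds shown also leave open how a methoxy group, a chlorine atom or an amine on this same aromatic carbon would compare with methyl and phenyl.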